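This account rests on a few compounds, and the source may have more. Where it says the series, first, only, none or still open, it means among the compounds named here.

Measured compounds:

compound 1, `O=C(Nc1cccc(C(F)(F)F)c1)c1cc(Cl)ccc1O`; in an ADME assay on cells (Macrophage, Mus musculus) for cytotoxicity, read by resazurin assay, with a stated time of 3 days (a higher number here means a weaker inhibitor, a lower number a stronger inhibitor), compound 1 gives 5900 nM
compound 2, `O=C(Nc1cccc(C(F)(F)F)c1C(F)(F)F)c1cc(Cl)ccc1O`; in this assay compound 2 gives 8100 nM
compound 3, `O=C(Nc1ccc(F)cc1)c1cc(Cl)ccc1O`; in this assay compound 3 gives 17000 nM

Compound 1 and compound 2 differ in one place: trifluoromethyl in place of hydrogen on an aromatic carbon. The step that this change made is a 1.4-fold higher number from compound 1 to compound 2 (0.14 log units; within the scatter). Compound 3 differs from compound 1 in more than one place; the difference between the two cores is not broken down here. Compound 3 has the highest number of the three, and its gaps to compound 2 and to compound 1 both lie beyond the usual scatter, so compound 3 is the weakest inhibitor of the measured set in this assay.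

Compound 4, `O=C(Nc1ccc(F)c(C(F)(F)F)c1)c1cc(Cl)ccc1O`, is not yet measured. It differs from compound 3 by trifluoromethyl in place of hydrogen on an aromatic carbon. This is the same kind of change as that from compound 1 to compound 2, but the surroundings differ: in compound 2 the place is ortho to a large group and ortho to a trifluoromethyl group, whereas in compound 4 it is ortho to a fluoro group and meta to a large group. Among the measured compounds shown here, only one measured instance of this change exists, so the expectation rests on a single step. For the measured compounds named here, the step expected here is a 1.3-fold higher number from compound 3 to compound 4 (0.11 log units; within the scatter), because the sole measured instance is a 1.4-fold higher number from compound 1 to compound 2 (0.14 log units; within the scatter), a step within the scatter. Compound 4 is therefore expected to give about 22000 nM in this assay, with a likely range from 10000 nM to 50000 nM.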

Compound 4, half-maximal inhibitory concentration: 5300 nM
For compound 4 the middle estimate is 4.2-fold (0.62 log units) above the measured one; the whole stated range lies above it.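

On the core of compound 3, trifluoromethyl in place of hydrogen on an aromatic carbon gives a 3.2-fold lower number from compound 3 to compound 4 (0.51 log units; beyond the scatter) in this assay, whereas fluoro in place of hydrogen on an aromatic carbon gives a 1.1-fold lower number from compound 1 to compound 4 (0.05 log units; within the scatter), so compound 1 and compound 4 cannot be told apart here. The two trifluoromethyl steps show only that, within these compounds, a step measured on one core cannot be carried over to another as a fixed increment, and they do not show what sets them apart, since the core and the surroundings of the new group both differ between the two instances. Among the compounds shown here, the single pair of instances gives no general rule for this series, and the comparison stands as follows: the same change on two cores in this assay, a 1.4-fold higher number (0.14 log units; within the scatter) from compound 1 to compound 2 and a 3.2-fold lower number (0.51 log units; beyond the scatter) from compound 3 to compound 4, 4.4-fold (0.64 log units) apart, beyond the scatter of two such steps.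

The compounds shown leave open whether trifluoromethyl placed ortho to a fluoro group on other cores would repeat the step seen on the core of compound 3, or whether that step belongs to compound 4 alone. They also leave open how a nitrile, an amine or a carboxylic acid in the place taken by trifluoromethyl would read in this assay.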